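Cyclohexyl for Furanylmethyl on an Amide Nitrogen

The compounds below may be only part of what the source reports. "The series", "measured", "known", "first", "only" and "open" are said of these compounds alone.

Compound 1 `N[C@H]1CC[C@H](Nc2c(C(=O)NCc3ccco3)nc(Br)c3cccnc23)CC1` has been tested in a functional assay on HCT-116 cells (Homo sapiens) for cytotoxicity, read by MTT assay, with a stated time of 72 h; a higher number here means a weaker inhibitor, a lower number a stronger inhibitor. In this assay compound 1 gives only a limit, > 10000 nM, not a number. Two other compounds built on the same core were run alongside it. Compound 2 `CC(C)(C)OC(=O)N1CCN(c2c(C(=O)NCc3ccc(F)cc3)nc(Br)c3cccnc23)CC1` also returns only a limit in this assay, > 10000 nM. Compound 3 `O=C(NCc1ccc(F)cc1)c1nc(Br)c2cccnc2c1NCc1ccccc1` returns only a limit as well, > 20000 nM. Taken together, the limit of > 10000 nM in this assay, at which 2 of the 3 values shown sit, and the limit of > 20000 nM in this assay, at which 1 of the 3 values shown sits, describe the whole picture: none of the three measured compounds produces a measurable effect, and compound 1 stands at the limit together with the others, with no number to rank it.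

Compound 4 `N[C@H]1CC[C@H](Nc2c(C(=O)NC3CCCCC3)nc(Br)c3cccnc23)CC1` has not yet been measured. It differs from compound 1 in a single place: cyclohexyl in place of (furan-2-yl)methyl on an amide-type nitrogen. Within the data shown here, no pair of measured compounds differs in only one place, so no measured step shows how large a change of this kind tends to be in this assay.

Because compound 1 gives > 10000 nM, compound 4 is expected to stay at or near the same limit, and the step that the limit leaves unreadable from compound 1 to compound 4 is expected to be none beyond the scatter. The estimate for compound 4 is 15000 nM, with a range from 5000 nM to 50000 nM.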

Compound 4, half-maximal inhibitory concentration: > 10000 nM
Compound 4 was reported as a limit; the forecaster's own chance of this, stated with the estimate: 75%; the middle value does not contradict the limit.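

Compound 4 gives > 10000 nM, which is a limit and not a number. Among these compounds, compound 1 also gives only a limit, so no step from compound 1 to compound 4 can be read. The compounds shown leave open whether cyclohexyl in place of (furan-2-yl)methyl changes anything, and whether any compound on the shared core would give a measurable value.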